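A Cytotoxicity Estimate for an Isopropylamino Analogue

This account rests on a few compounds, and the source may have more. Where it says the series, first, only, none or still open, it means among the compounds named here.

Compound 1 `Cc1ccc(S(=O)(=O)/N=C(/CCNC2=CC(=O)c3ccccc3C2=O)Nc2cccc(C)c2)cc1` was measured in an ADME assay on HEK293 cells (Homo sapiens) for cytotoxicity, read by MTT assay, with a stated time of 48 h (on this read-out lower numbers stand for stronger inhibition and higher numbers for weaker inhibition), where compound 1 gives 56200 nM. Compound 2 `COc1ccc(N/C(CCNC2=CC(=O)c3ccccc3C2=O)=N\S(=O)(=O)c2ccc(C)cc2)c(OC)c1` gives 83000 nM in this assay, and compound 3 `COc1cc(N/C(CCNC2=CC(=O)c3ccccc3C2=O)=N\S(=O)(=O)c2ccc(C)cc2)cc(OC)c1OC` gives 75800 nM. Compound 1 stands at one end of the three numbers, but both of its neighbours sit within the scatter of it: a 1.5-fold higher number from compound 1 to compound 2 (0.17 log units; within the scatter) and a 1.3-fold higher number from compound 1 to compound 3 (0.13 log units; within the scatter); likewise a 1.1-fold lower number from compound 2 to compound 3 (0.04 log units; within the scatter). Compound 4 `Cc1ccc(S(=O)(=O)/N=C(/CCNC2=CC(=O)c3ccccc3C2=O)NC(C)C)cc1` has not yet been measured in this assay. It differs from compound 1 in one place: isopropyl in place of 3-methylphenyl on an amine nitrogen. Among the compounds with values here, none of the measured steps exchanges an aryl group on that nitrogen for an alkyl group; all three steps exchange one aryl for another, and all three remain within the scatter. On that basis compound 4 is expected to show no shift beyond the scatter, an estimated step of a 1.2-fold higher number from compound 1 to compound 4 (0.06 log units; within the scatter). The number for compound 4 is therefore estimated at 65000 nM, within a range of 30000 nM to 140000 nM.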

Compound 4, half-maximal inhibitory concentration: 71600 nM
Compound 4: middle estimate off by 1.1-fold (0.04 log units), on the low side; the range from low to high includes it.
By their numbers in this assay, from the lowest: compounds 1, 4, 3 and 2 (each within the scatter of the next).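

Isopropyl, the first alkyl group on this amine nitrogen among these compounds, takes the place of an aromatic ring with no shift beyond the scatter in this assay: the steps are a 1.3-fold higher number from compound 1 to compound 4 (0.11 log units; within the scatter) and a 1.1-fold lower number from compound 3 to compound 4 (0.02 log units; within the scatter) and also a 1.2-fold lower number from compound 2 to compound 4 (0.06 log units; within the scatter) at this position. The earlier steps shown here only exchanged one aryl group for another, whereas these show that the number stays within the scatter even when the ring on this nitrogen is gone and a smaller, ring-free group stands there. Nothing available gives a cause for this result.

The compounds shown leave open whether a longer chain, or a chain ending in an amine or a carboxylic acid, on this nitrogen would move the number beyond the scatter. They also leave open whether a group as small as methyl would stay within it.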